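This account rests on a few compounds, and the source may have more. Where it says the series, first, only, none or still open, it means among the compounds named here.

Measured so far in an assay on HEK293 cells for inhibition of sodium-dependent dopamine transporter (Homo sapiens), read by scintillation counting; a lower number here means a stronger inhibitor, a higher number a weaker inhibitor:
Compound 1, `CN(C)CCC(c1ccc(Cl)c(Cl)c1)N1CCCCC1`: 602 nM
Compound 2, `CN(C)CCC(c1ccc(Cl)c(Cl)c1)N1CCCC1`: 357 nM

Compound 2 gives the lower of the two numbers, yet the gap to compound 1 is small: the step of a 1.7-fold lower number from compound 1 to compound 2 (0.23 log units; within the scatter) lies within the scatter of repeated measurements, so the two compounds cannot be told apart on these values.

Compound 3, `CCN(CC)CCC(c1ccc(Cl)c(Cl)c1)N1CCCC1`, keeps the core of compound 2 and differs from it in one place: diethylamino in place of dimethylamino on a saturated chain carbon, three bonds along the chain from an amine nitrogen in a ring and an aromatic carbon. Among the measured compounds shown here, no measured step bears on this change. For the measured compounds named here, the only step recorded, from compound 1 to compound 2, concerns the ring on the chain carbon and not the amine at the chain end, and it was itself within the scatter. With nothing in the data pointing either way, compound 3 is expected to stay close to compound 2, giving a step of a 1.3-fold higher number from compound 2 to compound 3 (0.10 log units; within the scatter) that should not exceed the scatter. The estimate for compound 3 in this assay is 450 nM, with a range from 180 nM to 1200 nM.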

Compound 3, half-maximal inhibitory concentration: 363 nM
Estimate against measurement, compound 3: 1.2-fold (0.09 log units) above, within the range that was stated.
By their numbers in this assay, from the lowest: compounds 2, 3 and 1 (each within the scatter of the next).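

In this assay, diethylamino in place of dimethylamino at this position gives a 1.0-fold higher number from compound 2 to compound 3 (0.01 log units; within the scatter), so compound 2 and compound 3 cannot be told apart on these values. Among the compounds shown here, this is the first reading at this position, and it shows that going from 3 to 5 heavy atoms in this group, with no ring and the same count of hydrogen-bond acceptors, leaves no difference that can be read beyond the scatter. Nothing further in the data bears on this result.

As far as these compounds go, it remains open whether the same would hold for dipropylamino or a primary amine at this position, or for a longer chain carrying the amine. From the compounds shown here alone, it is also open how diethylamino would read in this assay with piperidin-1-yl in place of pyrrolidin-1-yl on the shared core.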